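An ethoxy group added to the benzyl ether of compound 1

A few compounds are considered here, and "the series" means these few. Any claim that something is new, unique, unknown or untested is made for them only; others in the source may bear on it.

Compound 1 `COc1cccc(OC)c1OCCNCCOc1ccccc1OCc1ccccc1` gives 8.39 in a functional assay on Vas deferens for antagonist activity at Alpha-1A adrenergic receptor (Rattus norvegicus); a higher number here means a more potent compound, by a factor of ten per unit of this negative logarithm, a lower number a less potent compound; compound 2 `COc1cccc(COc2ccccc2OCCNCCOc2c(OC)cccc2OC)c1` gives 8.3 in this assay.

Going by the values given here, compound 1 stands highest of the two numbers, yet the only measured step, a number 0.09 log units lower from compound 1 to compound 2 (within the scatter), lies within the scatter, so the two compounds cannot be ranked. Compound 3 `CCOc1ccc(COc2ccccc2OCCNCCOc2c(OC)cccc2OC)cc1` differs from compound 1 by ethoxy in place of hydrogen on an aromatic carbon. Among the compounds with values here, the step from compound 1 to compound 2 is the one comparison that bears on this change, and it was flat. Compound 3 is therefore expected to show a step of a number 0.09 log units lower from compound 1 to compound 3 (within the scatter), nothing beyond the scatter. The estimate for compound 3 is 8.3, within 7.7 to 8.9.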

Compound 3, negative logarithm of the antagonist equilibrium constant: 8.5
For compound 3 the middle estimate is 0.20 log units below the measured one; low and high end bracket the measured number.
By their numbers in this assay, from the lowest: compounds 2, 1 and 3 (each within the scatter of the next).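

Ethoxy on the benzyl group gives a number 0.11 log units higher from compound 1 to compound 3 (within the scatter) so a group of 3 heavy atoms, para to a large group, leaves the number in this assay within the scatter. Exchanging 3-methoxyphenyl for 4-ethoxyphenyl gives a number 0.20 log units higher from compound 2 to compound 3 (within the scatter) so changing both the group and its place on this ring also produces no readable difference. No measured evidence on these compounds accounts for these results.

The compounds shown leave open whether an amine or a carboxylic acid at this para position would move the number beyond the scatter. They also leave open what a longer chain, such as butoxy, would do there.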